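Swapping the para group on an aryl thiocarbamate series

The compounds below may be only part of what the source reports. "The series", "measured", "known", "first", "only" and "open" are said of these compounds alone.

Measured so far in an ADME assay on MT4 cells (Homo sapiens) for cytotoxicity, read by MTT assay; a higher number here means that more compound is tolerated, a lower number that less compound is tolerated:
compound 1 `CCc1ccc(NC(=S)OCCc2ccccn2)cc1`, 44000 nM;
compound 2 `CC(C)c1ccc(NC(=S)OCCc2ccccn2)cc1`, 45000 nM;
compound 3 `S=C(Nc1ccc(I)cc1)OCCc1ccccn1`, 34000 nM.

All three share one core and differ only in the group on the outer aromatic ring. Compound 3 gives 34000 nM in this assay, and its steps to the other two, a 1.3-fold lower number from compound 1 to compound 3 (0.11 log units; within the scatter) and a 1.3-fold lower number from compound 2 to compound 3 (0.12 log units; within the scatter), both lie within the scatter, so compound 3 stands alongside compounds 1 and 2 rather than apart from them.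

Compound 4 `COc1ccc(NC(=S)OCCc2ccccn2)cc1` has not been measured. The change is methoxy in place of iodo on an aromatic carbon. The two steps that exchanged the group on that aromatic carbon, a 1.3-fold lower number from compound 1 to compound 3 (0.11 log units; within the scatter) and a 1.3-fold lower number from compound 2 to compound 3 (0.12 log units; within the scatter), stayed within the scatter, so no step beyond the scatter is expected in this assay for this change either. Compound 4 is therefore estimated at 40000 nM, between 20000 nM and 80000 nM, an expected step of a 1.2-fold higher number from compound 3 to compound 4 (0.07 log units; within the scatter).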

Compound 4, half-maximal cytotoxic concentration: 48000 nM
Beside the measured number, compound 4's estimate is 1.2-fold (0.08 log units) below it; the measured number falls inside the stated range.
By their numbers in this assay, from the lowest: compounds 3, 1, 2 and 4 (each within the scatter of the next).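

In this assay, methoxy brings an oxygen and a hydrogen-bond acceptor that iodo lacks, yet the step stays within the scatter (a 1.4-fold higher number from compound 3 to compound 4 (0.15 log units; within the scatter)). The same holds against the two alkyl groups (a 1.1-fold higher number from compound 1 to compound 4 (0.04 log units; within the scatter); a 1.1-fold higher number from compound 2 to compound 4 (0.03 log units; within the scatter)), so this aromatic carbon has now taken an oxygen-linked group as well as iodo and alkyl groups with no step beyond the scatter. No measured evidence explains this. Still open, on these data alone, is whether an amine, a carboxylic acid or a longer chain on this aromatic carbon would also stay within the scatter.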